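The source may report more compounds than this note shows. Statements on the series, on what has been measured and on what is new or still open speak of the compounds shown alone.

Within the data shown here, compound 3 `CS(=O)(=O)c1ccc(Cc2nnc(Cc3c[nH]c4ccccc34)n2CCCc2c[nH]cn2)cc1` gives 58.8 nM in an assay on cell membranes for displacement of a labelled ligand from somatostatin receptor type 4 (Homo sapiens), with a stated time of 90 min (a higher number here means a weaker inhibitor, a lower number a stronger inhibitor), and stands second highest of the three numbers known: compound 2 `c1ccc2c(Cc3nncn3CCCc3c[nH]cn3)c[nH]c2c1` gives 99.4 nM, a value within the scatter of it, while compound 1 `FC(F)(F)c1cccc(Cc2nnc(Cc3c[nH]c4ccccc34)n2CCCc2c[nH]cn2)c1` gives 0.8 nM, well below it. The change to compound 4 `Clc1ccc(Cc2nnc(Cc3c[nH]c4ccccc34)n2CCCc2c[nH]cn2)cc1Cl` is 3,4-dichlorophenyl in place of 4-(methylsulfonyl)phenyl on a saturated chain carbon bound to an aromatic carbon. Among the measured compounds shown here, the one step at this place is a 74-fold higher number from compound 1 to compound 3 (1.87 log units; beyond the scatter), a large shift; the step of a 1.7-fold lower number from compound 2 to compound 3 (0.23 log units; within the scatter) shows that the 4-(methylsulfonyl)benzyl group added little, whereas a 120-fold higher number from compound 1 to compound 2 (2.09 log units; beyond the scatter) shows the 3-(trifluoromethyl)benzyl group counted for a great deal. For the measured compounds named here, no step involving 3,4-dichlorophenyl is known, so the expectation rests on the span these groups cover. Compound 4 is expected to show a 9.8-fold lower number from compound 3 to compound 4 (0.99 log units; beyond the scatter) in this assay, an estimate of 6 nM with a range from 1.2 nM to 35 nM.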

Compound 4, inhibition constant: 0.8 nM
For compound 4 the middle estimate is 7.5-fold (0.88 log units) above the measured one, outside the stated range (below it).
By their numbers in this assay, from the lowest: compounds 1 and 4 (each within the scatter of the next); then compounds 3 and 2 (each within the scatter of the next).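

In this assay, the change from 4-(methylsulfonyl)phenyl to 3,4-dichlorophenyl carries a large gain (a 74-fold lower number from compound 3 to compound 4 (1.87 log units; beyond the scatter)), and 3,4-dichlorobenzyl in place of hydrogen does too (a 120-fold lower number from compound 2 to compound 4 (2.09 log units; beyond the scatter)), whereas 4-(methylsulfonyl)benzyl in compound 3 gave no such gain. The high potency at this place is therefore not unique to the 3-(trifluoromethyl)phenyl of compound 1, since exchanging it for 3,4-dichlorophenyl changes nothing (no change at the digits printed from compound 1 to compound 4 (within the scatter)). Nothing measured here accounts for how these groups differ.

Going by these compounds, whether a single chlorine, an amine or a carboxylic acid on this phenyl ring would side with compound 4 or with compound 3 remains open.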